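A few compounds are considered here, and "the series" means these few. Any claim that something is new, unique, unknown or untested is made for them only; others in the source may bear on it.

Compound 1 `Cc1cnoc1NS(=O)(=O)c1cccc2c(N(C)C)cccc12`: 4900 nM
Compound 2 `Cc1noc(NS(=O)(=O)c2cccc3c(N(C)C)cccc23)c1-c1ccccc1`: 15900 nM

In an assay on VSM-A10 cells for antagonist activity at Endothelin-1 receptor (Rattus norvegicus) (a lower number here means a stronger inhibitor, a higher number a weaker inhibitor), compound 1 gives 4900 nM, the lowest of the two numbers; compound 2 gives 15900 nM, a larger number that lies beyond the scatter. Within the data shown here, no pair of measured compounds differs in only one place, so no measured step is available. Compound 3 `CCc1noc(NS(=O)(=O)c2cccc3c(N(C)C)cccc23)c1C` differs from compound 1 by ethyl in place of hydrogen on an aromatic carbon. Among the measured compounds shown here, with only two measured values, the step is expected to stay within the scatter, so a 1.0-fold higher number from compound 1 to compound 3 (0.01 log units; within the scatter) is the estimate. Compound 3 is therefore expected to give about 5000 nM, with a range from 1500 nM to 16000 nM.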

Compound 3, half-maximal inhibitory concentration: 1170 nM
Estimate against measurement, compound 3: 4.3-fold (0.63 log units) above; measured number outside the range, below it.
By their numbers in this assay, from the lowest: compound 3; then compound 1; then compound 2.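

In this assay, placing ethyl on the aromatic carbon next to the ring nitrogen gives a stronger inhibitor (a 4.2-fold lower number from compound 1 to compound 3 (0.62 log units; beyond the scatter)). This shows that the position is not indifferent to substitution: a group with no ring and only two carbons is enough to move the number beyond the scatter. Nothing shown accounts for this gain. As far as these compounds go, whether a propyl group, a longer chain or an amine at this carbon would strengthen or weaken inhibition remains open. A single step cannot show how the effect varies with the group placed there.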